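The source may report more compounds than this note shows. Statements on the series, on what has been measured and on what is new or still open speak of the compounds shown alone.

Working notes on the series. The three measured compounds share one core and differ only on the saturated chain carbon bound to a saturated ring carbon. Compound 1 `CN(CCC#N)C[C@H]1CN(c2ccc(-n3cc(-c4ccccn4)cn3)c(F)c2)C(=O)O1` carries (2-cyanoethyl)(methyl)amino there; in an ADME assay on L02 cells (Homo sapiens) for cytotoxicity, read by MTT assay, with a stated time of 48 h (a lower number here means a stronger inhibitor, a higher number a weaker inhibitor), compound 1 gives only a limit, > 400 ug/mL. Compound 2 `CC(=O)OC[C@H]1CN(c2ccc(-n3cc(-c4ccccn4)cn3)c(F)c2)C(=O)O1` carries acetoxy; in this assay compound 2 also gives only a limit, > 400 ug/mL. Among the compounds with values here, compound 3 `CCC(=O)NC[C@H]1CN(c2ccc(-n3cc(-c4ccccn4)cn3)c(F)c2)C(=O)O1` carries propanoylamino, and in this assay compound 3 gives 204 ug/mL, the only number in the set. The steps of an at least 1.9-fold lower number from compound 1 to compound 3 (0.29 log units; that floor lies within the scatter) and an at least 1.9-fold lower number from compound 2 to compound 3 (0.29 log units; that floor lies within the scatter) are read against (the limit of > 400 ug/mL in this assay, at which 2 of the 3 values shown sit), so their size is known only as a floor; the step that the two limits leave unreadable from compound 1 to compound 2 cannot be read at all.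

Compound 4 `NC(=O)[C@H]1CN(c2ccc(-n3cc(-c4ccccn4)cn3)c(F)c2)C(=O)O1` differs from compound 3 by carbamoyl in place of (propanoylamino)methyl on a saturated ring carbon. Within the data shown here, no measured step exchanges one amide-bearing group for another, so the steps from compound 1 and compound 2 to compound 3 bear only loosely: they show that the propanoylamino compound 3 sits lower than the two limits, while compound 4 drops that group. The expected step of a 1.7-fold higher number from compound 3 to compound 4 (0.23 log units; within the scatter) is towards a somewhat higher number, without confidence beyond the scatter. For compound 4 the estimate in this assay is 350 ug/mL, ranging from 150 ug/mL to 800 ug/mL, with a fair chance that only a limit is reported.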

Compound 4, half-maximal inhibitory concentration: 119 ug/mL
Beside the measured number, compound 4's estimate is 2.9-fold (0.47 log units) above it; measured number outside the range, below it.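

Carbamoyl on the saturated ring carbon in place of (propanoylamino)methyl gives a 1.7-fold lower number from compound 3 to compound 4 (0.23 log units; within the scatter) in this assay, so this exchange of one amide-bearing group for another leaves the two numbers unseparated. Within the data shown here, the new floors, an at least 3.3-fold lower number from compound 2 to compound 4 (0.52 log units; beyond the scatter) and an at least 3.3-fold lower number from compound 1 to compound 4 (0.52 log units; beyond the scatter), are the first steps at this position that clear the scatter, whereas the floors for the steps to compound 3 stayed within it, so the set offers only a loose contrast between the two amide-bearing groups and the acetoxymethyl and ((2-cyanoethyl)(methyl)amino)methyl groups. Both new floors are read against the limits of compound 1 and compound 2, so their true size stays unknown: the limit of > 400 ug/mL in this assay, at which 2 of the 4 values shown sit.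

Still open, from the compounds shown here alone, is whether the amide itself matters at this ring carbon, since a carboxylic acid in place of carbamoyl or an aminomethyl group in place of (propanoylamino)methyl would test that directly. Also open is whether a longer acyl chain than propanoyl would move the number at all, since the two amide-bearing groups shown do not separate.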